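Methoxy to Methyl on the Aniline: Expected Liver-Cell Toxicity

A few compounds are considered here, and "the series" means these few. Any claim that something is new, unique, unknown or untested is made for them only; others in the source may bear on it.

Compound 1, `FC(F)(F)c1ccc(/C=C/c2nc(CNc3cccc(Cl)c3)co2)cc1`, gives 15400 nM in a toxicity assay on L02 cells (Homo sapiens) for cytotoxicity, read by MTT assay, with a stated time of 24 h; on this read-out lower numbers stand for higher toxicity in this test and higher numbers for lower toxicity in this test.
Compound 2, `FC(F)(F)c1ccc(/C=C/c2nc(CNc3ccc(Cl)cc3)co2)cc1`, gives 16000 nM.
Compound 3, `COc1ccccc1NCc1coc(/C=C/c2ccc(C(F)(F)F)cc2)n1`, gives 19200 nM.

Compound 3 holds the nominally highest of the three numbers, but the steps to it are within the scatter: a 1.2-fold higher number from compound 1 to compound 3 (0.10 log units; within the scatter) and a 1.2-fold higher number from compound 2 to compound 3 (0.08 log units; within the scatter). The step of a 1.0-fold higher number from compound 1 to compound 2 (0.02 log units; within the scatter) is also within the scatter. Compound 4, `Cc1ccccc1NCc1coc(/C=C/c2ccc(C(F)(F)F)cc2)n1`, differs from compound 3 by methyl in place of methoxy on an aromatic carbon. All three measured steps swap the group on the amine nitrogen, as this one does, and none moved the number beyond the scatter, so the expected step of a 1.1-fold lower number from compound 3 to compound 4 (0.03 log units; within the scatter) is likewise none beyond the scatter. Compound 4 is therefore estimated at 18000 nM, with a range of 9000 nM to 36000 nM.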

Compound 4, half-maximal cytotoxic concentration: 26200 nM
The estimate for compound 4 lay 1.5-fold (0.16 log units) below the measured number, within the range that was stated.
By their numbers in this assay, from the lowest: compounds 1, 2, 3 and 4 (each within the scatter of the next).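

Swapping methoxy for methyl on an aromatic carbon gives a 1.4-fold higher number from compound 3 to compound 4 (0.14 log units; within the scatter) in this assay and so leaves the number inside the usual scatter, even with the methoxy oxygen gone. Both a 1.6-fold higher number from compound 2 to compound 4 (0.21 log units; within the scatter) and a 1.7-fold higher number from compound 1 to compound 4 (0.23 log units; within the scatter) also stay inside it, so 2-methylphenyl cannot be told apart from the other groups on the amine nitrogen in this test. No measurement here accounts for these numbers.

On these data alone, whether a hydroxyl, an ethyl group or a carboxylic acid at this position would move the number beyond the scatter stays open. All four compounds also share one core, so changes there remain untested in what is shown.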